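Shortening the Ether Chain of a Chalcone Core

The source may hold more compounds than are shown below. What is called first, only, known or untested is meant among the compounds shown, and "the series" means these compounds.

Measured compounds:
compound 1, `O=C(/C=C/c1ccc(O)cc1)c1c(O)cccc1OCCC1CCCC1`: 3200 nM
compound 2, `CC(C)(C)CCOc1cccc(O)c1C(=O)/C=C/c1ccc(S(N)(=O)=O)cc1`: 1170 nM

In a functional assay on NUGC-3 cells (Homo sapiens) for antiproliferative activity, read by sulforhodamine B assay (on this read-out lower numbers stand for stronger inhibition of growth and higher numbers for weaker inhibition of growth), compound 1 gives 3200 nM, the highest of the two numbers shown; compound 2 gives 1170 nM, a gap beyond the scatter. Compound 3, `CC(C)COc1cccc(O)c1C(=O)/C=C/c1ccc(O)cc1`, differs from compound 1 in a single place: isopropyl in place of cyclopentylmethyl on a saturated chain carbon bound to an oxygen on an aromatic ring. Within the data shown here, no measured pair isolates this change, so the step is expected to be modest, if anything toward weaker inhibition of growth. Compound 3 is therefore estimated at 4000 nM, in the range 1500 nM to 10000 nM, which is the expected step of a 1.3-fold higher number from compound 1 to compound 3 (0.10 log units; within the scatter).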

Compound 3, concentration for 50% growth inhibition: 2980 nM
Compound 3: the middle estimate sits 1.3-fold (0.13 log units) above what was measured, within the range that was stated.
By their numbers in this assay, from the lowest: compound 2; then compounds 3 and 1 (each within the scatter of the next).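

In this assay, isopropyl in place of cyclopentylmethyl on a saturated chain carbon bound to an oxygen on an aromatic ring gives a 1.1-fold lower number from compound 1 to compound 3 (0.03 log units; within the scatter). At this position, then, the 6-carbon group with its five-membered ring and the 3-carbon group without a ring cannot be told apart by growth inhibition. No evidence at hand bears on this result.

The compounds shown leave open whether a much longer chain would keep growth inhibition at this level. They also leave open whether an amine or a carboxylic acid on the chain would do so.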